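The source may report more compounds than this note shows. Statements on the series, on what has been measured and on what is new or still open speak of the compounds shown alone.

Measured so far in a functional assay, read by spectrophotometry, with a stated time of 2 h, tested at 2.5 mg/mL; a higher number here means a stronger effect of the compound at the concentration tested, a lower number a weaker effect:

compound 1, `CC(C)[C@@H]1CC[C@@H](C)C[C@@]12N(C)C(=O)[C@@H]1[C@H]3C(=O)N(c4ccc(Cl)cc4)C(=O)[C@H]3ON12`: 61.3%
compound 2, `COc1ccc(N2C(=O)[C@H]3[C@H](ON4[C@@H]3C(=O)N(C)[C@@]43C[C@H](C)CC[C@H]3C(C)C)C2=O)cc1`: 59.3%

Among the compounds with values here, compound 2 holds one of only two numbers, and the other belongs to compound 1; the step of a number 2 percentage points lower from compound 1 to compound 2 (within the scatter) separates them, so the two compounds cannot be told apart on this assay. Compound 3, `Cc1cccc(N2C(=O)[C@H]3[C@H](ON4[C@@H]3C(=O)N(C)[C@@]43C[C@H](C)CC[C@H]3C(C)C)C2=O)c1`, is not yet measured. It differs from compound 2 in one place: 3-methylphenyl in place of 4-methoxyphenyl on an amide-type nitrogen in a ring. Within the data shown here, the only measured step that touches the same aromatic ring is the one from compound 1 to compound 2, a number 2 percentage points lower from compound 1 to compound 2 (within the scatter), which stayed within the scatter. Among the measured compounds shown here, there is no measured step that swaps a methoxy for a methyl or moves a group on this ring, so the expectation rests on that single step alone. The step from compound 2 to compound 3 is therefore expected to be a number 0.7 percentage points higher from compound 2 to compound 3 (within the scatter), nothing beyond the scatter in either direction. Compound 3 is estimated to give 60%, with a likely range from 48% to 71%.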

Compound 3, a percentage reported as activity, at one concentration (the size of the read-out at that concentration, not a potency): 57.6%
The estimate for compound 3 lay 2.4 percentage points above the measured number, and the stated range covers the measured number.
By their numbers in this assay, from the lowest: compounds 3, 2 and 1 (each within the scatter of the next).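

In this assay, the step of a number 1.7 percentage points lower from compound 2 to compound 3 (within the scatter) shows that the read-out stays within the scatter even when 3-methylphenyl replaces 4-methoxyphenyl on the amide-type nitrogen, a swap that removes the hydrogen-bond acceptor of the leaving group. The step of a number 3.7 percentage points lower from compound 1 to compound 3 (within the scatter) gives the same picture for 3-methylphenyl in place of 4-chlorophenyl, so the three aromatic groups at this nitrogen cannot be told apart on this assay. No supporting data bear on why these numbers stay so close.

Still open, going by these compounds, is whether a very different group on this nitrogen, such as a ring carrying an amine or a carboxylic acid, or a plain alkyl chain instead of an aromatic ring, would move the number beyond the scatter. Within the data shown here, these three compounds also cannot show whether moving a single group around the ring matters, since no pair carries the same group in two places.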